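The source may hold more compounds than are shown below. What is called first, only, known or untested is meant among the compounds shown, and "the series" means these compounds.

In an ADME assay on MCF-10A cells (Homo sapiens) for inhibition, with a stated time of 48 h (a lower number here means a stronger inhibitor, a higher number a weaker inhibitor), compound 1 (`O=C(Nc1ccc(Cl)cc1)N1CCC[C@H]1c1nc(-c2ccccc2)no1`) reads > 50000 nM, which is a limit of the assay and not a number. Compound 2 (`O=C(Nc1ccc(Cl)cc1)N1CCC[C@H]1c1nc(-c2ccccc2F)no1`) reads > 50000 nM, again a limit. Compound 3 (`O=C(Nc1ccc(Cl)cc1)N1CCC[C@H]1c1nc(-c2ccccc2Cl)no1`) reads > 50000 nM, also a limit, so it has no exact position on the scale. The whole set stands at one place: the limit of > 50000 nM in this assay, at which 3 of the 3 values shown sit.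

Compound 4 (`O=C(Nc1ccc(Cl)cc1)N1CCC[C@H]1c1nc(-c2ccccc2Br)no1`) differs from compound 3 in a single change: bromo in place of chloro on an aromatic carbon. That is bromo in place of chloro on an aromatic carbon, ortho to a large group.

Among the measured compounds shown here, three measured steps bear on this change, each a single swap on an aromatic carbon: a step that the two limits leave unreadable from compound 1 to compound 2, a step that the two limits leave unreadable from compound 1 to compound 3 and a step that the two limits leave unreadable from compound 2 to compound 3. None of them has a readable size, so they point in no direction, and no step beyond the scatter is expected in this assay. The expected step is a step that the limit leaves unreadable from compound 3 to compound 4, and this estimate is a loose one. Another limit is the most likely report. For compound 4, the estimated value is 60000 nM, with an expected range from 25000 nM to 150000 nM.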

Compound 4, half-maximal inhibitory concentration: > 50000 nM
Compound 4 ended at the assay's limit; the forecaster's own chance of this, stated with the estimate: 80%; the middle value lies beyond the limit too.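

Compound 4 gives > 50000 nM in this assay, which is a limit of the assay and not a number. Its steps from compound 1, compound 2 and compound 3 therefore cannot be read. The compounds shown leave open whether hydrogen, fluoro, chloro or bromo at this place changes inhibition at all, as the set gives only one reading: the limit of > 50000 nM in this assay, at which 4 of the 4 values shown sit.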